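Cytotoxicity notes on the shared core series

The source may report more compounds than this note shows. Statements on the series, on what has been measured and on what is new or still open speak of the compounds shown alone.

Measured so far in an ADME assay on HEL cells (Homo sapiens) for cytotoxicity, with a stated time of 3 days; on this read-out lower numbers stand for higher toxicity in this test and higher numbers for lower toxicity in this test:
- compound 1, `CCC1(Cc2ccccc2)OS(=O)(=O)C=C1OCC1CCCCC1`: >= 200000 nM
- compound 2, `CCC1(Cc2ccccc2)OS(=O)(=O)C=C1NCc1ccccc1`: >= 80000 nM

Compound 1 stands only at a limit of this assay; the value >= 200000 nM given for compound 1 is a limit of the test and not a number. Compound 2 likewise gives a limit, >= 80000 nM. For the measured compounds named here, the one measured step, a step that the two limits leave unreadable from compound 1 to compound 2, cannot be read in size or direction because the limit of >= 200000 nM in this assay, at which 1 of the 2 values shown sits, and the limit of >= 80000 nM in this assay, at which 1 of the 2 values shown sits, place both values at limits of the test.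

Compound 3, `CCC1(Cc2ccccc2)OS(=O)(=O)C=C1OC(=O)c1ccccc1`, differs from compound 1 in one place: benzoyl in place of cyclohexylmethyl on an oxygen on an unsaturated carbon. Going by the values given here, no measured step matches this change, and the single step in the set is unreadable, so nothing in the numbers argues for a move beyond the usual scatter in this assay.

On that basis compound 3 is expected to sit at about 150000 nM in this assay, with a likely range of 40000 nM to 300000 nM. The step of an at least 1.3-fold lower number from compound 1 to compound 3 (0.12 log units; that floor lies within the scatter) this implies is expected to stay within the scatter, and a limit rather than a number is thought the most probable outcome for compound 3.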

Compound 3, minimum cytotoxic concentration: > 400000 nM
Compound 3: only a limit was reported; the forecaster's own chance of this, stated with the estimate: 65%; middle value at least 2.6-fold (0.42 log units) from the limit.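

In this assay compound 3 gives > 400000 nM, which is a limit and not a number. For the compounds shown here, with compound 1 also at a limit, no step from compound 1 to compound 3 can be read. The compounds shown leave open how far compound 1, compound 2 and compound 3 truly differ in this assay, since none has a number.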